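Trading an Isopropoxy for a Trifluoromethoxy Group

The source may report more compounds than this note shows. Statements on the series, on what has been measured and on what is new or still open speak of the compounds shown alone.

Compound 1 `CC(C)Oc1cccc(NC(=O)CN2CCC(c3cccc[n+]3[O-])CC2)c1` holds the higher of two numbers in a functional assay on HEK293 cells for agonist activity at D(4) dopamine receptor (Homo sapiens), read by FLIPR; a higher number here means that more compound is needed for the effect, a lower number that less compound is needed: compound 1 gives 555 nM, whereas compound 2 `COc1cccc(C)c1NC(=O)CN1CCC(c2ccccn2)CC1` gives 40 nM, a lower number beyond the usual scatter. Compound 3 `O=C(CN1CCC(c2cccc[n+]2[O-])CC1)Nc1cccc(OC(F)(F)F)c1` keeps the core of compound 1 and differs in one place: trifluoromethyl in place of isopropyl on an oxygen on an aromatic ring. Among the measured compounds shown here, no measured pair shows this kind of change, so its direction is open. The expected step is a 1.1-fold lower number from compound 1 to compound 3 (0.05 log units; within the scatter), no larger than the scatter. Compound 3 is therefore estimated at 500 nM, with a likely range from 150 nM to 1800 nM.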

Compound 3, half-maximal effective concentration: 135 nM
Beside the measured number, compound 3's estimate is 3.7-fold (0.57 log units) above it, and the stated range ends above it.
By their numbers in this assay, from the lowest: compound 2; then compound 3; then compound 1.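

Swapping isopropoxy for trifluoromethoxy gives a 4.1-fold lower number from compound 1 to compound 3 (0.61 log units; beyond the scatter) in this assay and so shows that the number responds to the group on this oxygen, with the core of compound 1 left unchanged. This first measured pair of its kind gives the change a direction, though only on this one core. Nothing measured here explains the shift.

Still open, on these data alone, is where an ethoxy group, a hydroxyl group or a longer chain such as butoxy would fall at this position. Also open, as far as these compounds go, is whether the same swap moves the number the same way on another core.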